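Swapping the Ortho Substituent on the Aryl Piperazine

The source may hold more compounds than are shown below. What is called first, only, known or untested is meant among the compounds shown, and "the series" means these compounds.

Measured so far:
compound 1 `CCCc1nc(-c2ccccc2)c(CNCCCN2CCN(c3ccccc3Cl)CC2)o1` 64.7%
compound 2 `CCCc1nc(-c2ccccc2)c(CNCCCN2CCN(c3ccc(C(F)(F)F)cc3)CC2)o1` 51.6%
compound 3 `CCCc1nc(-c2ccccc2)c(CNCCCN2CCN(c3ccccc3C(F)(F)F)CC2)o1` 45%

In an assay on HEK293 cells for inhibition of Voltage-dependent T-type calcium channel subunit alpha-1G (Homo sapiens), read by fluorescence, tested at 10 uM (on this read-out higher numbers stand for more inhibition at the one concentration tested (going by the name of the read-out) and lower numbers for less inhibition), compound 3 gives 45%, the lowest of the three numbers; it is within the scatter of compound 2 but clearly beyond it from compound 1. Compound 4 `CCCc1nc(-c2ccccc2)c(CNCCCN2CCN(c3ccccc3OC)CC2)o1` differs from compound 3 by methoxy in place of trifluoromethyl on an aromatic carbon. Among the compounds with values here, the one step that bears on this is a number 19.7 percentage points lower from compound 1 to compound 3 (beyond the scatter), which shows that the group at this position does shift the read-out by a modest amount. No methoxy at this position has been measured, so the direction rests on that single step alone. Compound 4 is therefore expected to move by a number 10 percentage points higher from compound 3 to compound 4 (within the scatter) in this assay. The estimate for compound 4 is 55%, with a range from 35% to 75%.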

Compound 4, a percentage reported as inhibition, at one concentration (the size of the read-out at that concentration, not a potency): 41%
Compound 4: middle estimate off by 14 percentage points, on the high side; measured number inside the range.
By their numbers in this assay, from the lowest: compounds 4, 3 and 2 (each within the scatter of the next, the first and the last beyond it); then compound 1.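

In this assay, methoxy and trifluoromethyl on this aromatic carbon cannot be told apart, with a number 4 percentage points lower from compound 3 to compound 4 (within the scatter), while chloro now stands clear of two other groups, with a number 23.7 percentage points lower from compound 1 to compound 4 (beyond the scatter). The change from 4-(trifluoromethyl)phenyl to 2-methoxyphenyl, unlike the one to 2-(trifluoromethyl)phenyl, goes beyond the scatter, with a number 10.6 percentage points lower from compound 2 to compound 4 (beyond the scatter). Nothing measured here gives a reason for these results.

Still open, going by these compounds, is whether fluoro, bromo or methyl on this carbon would match chloro, and whether chloro elsewhere on the ring would hold the same reading.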